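Methoxy additions on a shared core: working notes

The source may hold more compounds than are shown below. What is called first, only, known or untested is meant among the compounds shown, and "the series" means these compounds.

Measured so far, all in a functional assay on HT-29 cells (Homo sapiens) for cytotoxicity, read by MTT assay, with a stated time of 3 days; on this read-out higher numbers stand for weaker inhibition and lower numbers for stronger inhibition:
compound 1, `COc1ccccc1-c1cccc(O)c1`, where compound 1 gives 22 ug/mL
compound 2, `COc1ccc(-c2ccccc2)cc1`, where compound 2 gives 45 ug/mL
compound 3, `COc1ccc(-c2cccc(O)c2)c(OC)c1`, where compound 3 gives 54 ug/mL

The difference between the cores of compound 1 and compound 2 is not broken down here; their values show compound 2 with the higher number. Compound 2 and compound 3 lie within the scatter of each other, so no order is read between them.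

One single-point change is measured on the series. methoxy in place of hydrogen on an aromatic carbon gives a 2.5-fold higher number from compound 1 to compound 3 (0.39 log units; beyond the scatter), a modest weakening.

Compound 4, `COc1ccc(-c2ccccc2)cc1OC`, is not yet measured. It differs from compound 2 by methoxy in place of hydrogen on an aromatic carbon. This is the same kind of change as from compound 1 to compound 3, not the same change: there the entering methoxy sat meta to a methoxy group and para to a group of 7 heavy atoms, here it sits ortho to a methoxy group and meta to a group of 6 heavy atoms. For the measured compounds named here, the single measured example is the only guide, and its surroundings differ, so the expectation is held loosely.

A step of similar size is expected from compound 2 to compound 4, a 2.0-fold higher number from compound 2 to compound 4 (0.30 log units; within the scatter), resting on a 2.5-fold higher number from compound 1 to compound 3 (0.39 log units; beyond the scatter). Compound 4 is therefore expected near 90 ug/mL in this assay, with a plausible range of 45 ug/mL to 180 ug/mL. Given the starting value of compound 2, 45 ug/mL, a reading for compound 4 near the upper end of that range is a real possibility.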

Compound 4, half-maximal inhibitory concentration: 41 ug/mL
Compound 4: the middle estimate sits 2.2-fold (0.34 log units) above what was measured; measured number below the stated range.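

In this assay, the second example of methoxy in place of hydrogen on an aromatic carbon gives a 1.1-fold lower number from compound 2 to compound 4 (0.04 log units; within the scatter), so no effect of the added methoxy can be read on this core. The change therefore does not carry over as one fixed step between these two cores, and the gap between the two examples is larger than scatter alone would account for: the same change on two cores in this assay, a 2.5-fold higher number (0.39 log units; beyond the scatter) from compound 1 to compound 3 and a 1.1-fold lower number (0.04 log units; within the scatter) from compound 2 to compound 4, 2.7-fold (0.43 log units) apart, beyond the scatter of two such steps. This shows that the modest weakening seen on the core of compound 1 cannot be assumed on the core of compound 2, but it does not show what separates the two cases, as the cores differ and the entering methoxy also has different surroundings in each, and two examples support no rule for the series.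

The compounds shown leave open whether the methoxy would give a third result at other places on these cores, and how much the hydroxy group on the core of compound 1 contributes on its own. They also leave open how this assay would respond if an amine, a carboxylic acid or a longer alkoxy chain entered at the same place as the methoxy.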